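This account rests on a few compounds, and the source may have more. Where it says the series, first, only, none or still open, it means among the compounds named here.

In a functional assay on HCT-116 cells (Homo sapiens), read by MTT assay, with a stated time of 72 h (on this read-out lower numbers stand for stronger inhibition and higher numbers for weaker inhibition), compound 1 `CSc1ncnc2c1c(-c1ccoc1)cn2[C@@H]1O[C@H](CO)[C@@H](O)[C@H]1O` gives 40 nM. Compound 2 `CSc1ncnc2c1c(-c1cccs1)cn2[C@@H]1O[C@H](CO)[C@@H](O)[C@H]1O` gives > 20000 nM, which is a limit of the assay and not a number. It therefore has no exact position in the series: the limit of > 20000 nM in this assay, at which 1 of the 2 values shown sits.

Compound 3 `CSc1ncnc2c1c(-c1ccsc1)cn2[C@@H]1O[C@H](CO)[C@@H](O)[C@H]1O` carries thiophen-3-yl in place of thiophen-2-yl on an aromatic carbon, so the two have the same atoms, joined differently. Going by the values given here, the only measured step bearing on this is an at least 500-fold higher number from compound 1 to compound 2 (2.69 log units; beyond the scatter), large and beyond the scatter, with thiophen-2-yl in place of furan-3-yl. Compound 3 shares the 3-yl naming of its ring with compound 1, which stands at 40 nM. A large move toward lower numbers in this assay is therefore expected, though this rests on one step and a limit remains possible. The expected change is an at least 66-fold lower number from compound 2 to compound 3 (1.82 log units; beyond the scatter). For compound 3 the estimate is 300 nM, with an expected range of 40 nM to 8000 nM.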

Compound 3, half-maximal inhibitory concentration: > 20000 nM
Compound 3: only a limit was reported; the forecaster's own chance of this, stated with the estimate: 20%; middle value at least 66-fold (1.82 log units) away from the limit.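

In this assay compound 3 gives > 20000 nM, which is a limit of the assay and not a number. Sharing the 3-yl naming with compound 1 therefore does not keep the low value at this aromatic carbon, and replacing furan-3-yl with thiophen-3-yl gives an at least 500-fold higher number from compound 1 to compound 3 (2.69 log units; beyond the scatter), so the loss now appears with both thiophene isomers, and the step between those two isomers cannot be read. The thiophene pair therefore gives no order at this position, only a shared limit: the limit of > 20000 nM in this assay, at which 2 of the 3 values shown sit.

The compounds shown leave open whether the low value of compound 1 belongs to furan-3-yl alone or extends to furan-2-yl. They also leave open how a phenyl ring or a small group such as methyl would read at this carbon.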